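This account rests on a few compounds, and the source may have more. Where it says the series, first, only, none or still open, it means among the compounds named here.

Measured so far:
- compound 1 `Nc1cc(N)c2nc(-c3ccccc3)c(Oc3ccc(Cl)c(Cl)c3)nc2c1` — < 100000 nM
- compound 2 `CCOC(=O)[C@H](CCC(=O)O)NC(=O)c1ccc(Sc2nc3cc(N)cc(N)c3nc2-c2ccccc2)cc1` — < 100000 nM

In a functional assay on SK-OV-3 cells (Homo sapiens) for inhibition, read by sulforhodamine B assay, with a stated time of 48 h (a lower number here means that less compound is tolerated, a higher number that more compound is tolerated), compound 1 gives < 100000 nM, which is a limit of the assay and not a number. In this assay compound 2 likewise gives < 100000 nM, also a limit. Compound 1 therefore stands at the limit of < 100000 nM in this assay, at which 2 of the 2 values shown sit; no measured number places it above or below compound 2, and nothing more can be said of the pair.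

Compound 3 `Nc1cc(N)c2nc(-c3ccccc3)c(Sc3ccc(Cl)c(Cl)c3)nc2c1` has not yet been measured. The change from compound 1 is (3,4-dichlorophenyl)sulfanyl in place of 3,4-dichlorophenoxy on an aromatic carbon. Among the measured compounds shown here, no measured step between two compounds is available, so the size of the change cannot be read from the data. The expected step that the limit leaves unreadable from compound 1 to compound 3 is small, with a fair chance that compound 3 again reports only a limit. For compound 3 the estimate in this assay is 30000 nM, expected to fall between 5000 nM and 100000 nM.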

Compound 3, concentration lethal to 50% of the cells: < 100000 nM
Compound 3 was reported as a limit; the forecaster's own chance of this, stated with the estimate: 50%; the middle value does not contradict the limit.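

In this assay compound 3 gives < 100000 nM, a limit and not a number. Among the compounds shown here, compound 1 and compound 3 both report only a limit, and no step between them can be read. Still open, going by these compounds, is whether (3,4-dichlorophenyl)sulfanyl in place of 3,4-dichlorophenoxy changes the value at all.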